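The source may report more compounds than this note shows. Statements on the series, on what has been measured and on what is new or still open speak of the compounds shown alone.

Compound 3 `COc1ccc(N(Cc2ccccc2F)NC(=O)NCCCN2CCN(c3ccccc3OC)CC2)cc1` gives 2.6 nM in an assay on CHO cells for displacement of a labelled ligand from D(4) dopamine receptor (Homo sapiens), read by radioligand binding; on this read-out higher numbers stand for weaker inhibition and lower numbers for stronger inhibition. Among the three compounds measured there it holds the second highest number: compound 1 `COc1ccccc1N1CCN(CCCNC(=O)NN(Cc2cccc(F)c2)c2ccc(F)cc2)CC1` gives 3.8 nM, and compound 2 `COc1ccc(N(Cc2ccccc2)NC(=O)NCCCN2CCN(c3ccccc3OC)CC2)cc1` gives 1.7 nM, both within the scatter of compound 3. Compound 4 `COc1ccc(N(Cc2cccc(F)c2)NC(=O)NCCCN2CCN(c3ccccc3OC)CC2)cc1` differs from compound 3 by 3-fluorophenyl in place of 2-fluorophenyl on a saturated chain carbon bound to a nitrogen on an aromatic ring. For the measured compounds named here, the only measured step touching a fluorine on this benzyl group is a 1.5-fold higher number from compound 2 to compound 3 (0.18 log units; within the scatter), which stayed within the scatter, and no measured pair moves the fluorine from one position of that ring to another. Compound 4 is therefore expected to give a number close to that of compound 3, with a step of a 1.2-fold higher number from compound 3 to compound 4 (0.06 log units; within the scatter) and an estimate of 3 nM ranging from 1.2 nM to 7.5 nM.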

Compound 4, inhibition constant: 6.2 nM
For compound 4 the middle estimate is 2.1-fold (0.32 log units) below the measured one; low and high end bracket the measured number.
By their numbers in this assay, from the lowest: compounds 2, 3, 1 and 4 (each within the scatter of the next, the first and the last beyond it).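

In this assay the place of the fluorine on this benzyl group does count, with a 2.4-fold higher number from compound 3 to compound 4 (0.38 log units; beyond the scatter) for 3-fluorophenyl in place of 2-fluorophenyl, whereas compound 3 had stayed within the scatter of compound 2. With fluoro in place of hydrogen on an aromatic carbon, the step of a 3.6-fold higher number from compound 2 to compound 4 (0.56 log units; beyond the scatter) shows that a fluorine on this ring can matter, but only in the 3-fluorophenyl form. Methoxy in place of fluoro on an aromatic carbon gives a 1.6-fold higher number from compound 1 to compound 4 (0.21 log units; within the scatter) and no change can be read from it.

Nothing given here accounts for the effect of the fluorine's place.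
On these data alone, whether chloro or trifluoromethyl in place of the fluoro on this benzyl group would behave alike stays open.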